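This account rests on a few compounds, and the source may have more. Where it says the series, first, only, none or still open, it means among the compounds named here.

Compounds measured so far:
compound 1 `CN1C[C@H]2C=C(c3cccnc3)C[C@H](C2)C1` 3500 nM
compound 2 `C1=C(c2cccnc2)C[C@@H]2CNC[C@H]1C2` 50 nM
compound 3 `C1=C(c2cncc(Oc3ccccc3)c2)CC2CNCC1C2` 590 nM

Compound 1, whose structure is `CN1C[C@H]2C=C(c3cccnc3)C[C@H](C2)C1`, gives 3500 nM in an in vitro functional assay on SH-EP1 cells for agonist activity at Neuronal acetylcholine receptor; alpha4/beta2 (Homo sapiens), read by voltage clamp (on this read-out higher numbers stand for an effect only at larger amounts of compound and lower numbers for an effect already at smaller amounts), the highest of the three numbers. Compound 3 stands nearest to it with 590 nM, a gap beyond the scatter, and compound 2 stands furthest with 50 nM, also beyond the scatter. Within the data shown here, no pair among the three differs in a single place, so no counted step between measured compounds is available.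

Compound 4, drawn as `CN1C[C@@H]2C=C(c3cccnc3)C[C@@H](C2)C1`, has not yet been measured. Compared with compound 1, (the two compounds have the same atoms and bonds and differ only in configuration as drawn: 2 of 2 stereo elements differ (all stereocentres are inverted: mirror images); a stereocentre at a saturated ring carbon is drawn R in compound 1 and S in compound 4; a stereocentre at a saturated ring carbon is drawn S in compound 1 and R in compound 4). Among the measured compounds shown here, the set contains no pair of mirror images with known values, so the size and direction of such a change here cannot be read from the measured compounds; mirror images of this kind are often far apart in this assay, but nothing here shows which way. The writer therefore expects for compound 4 a step from compound 1 of a 2.3-fold lower number from compound 1 to compound 4 (0.37 log units; beyond the scatter), with a wide range on either side. Compound 4 is estimated at 1500 nM, within 300 nM to 8000 nM.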

Compound 4, half-maximal effective concentration: 3100 nM
Beside the measured number, compound 4's estimate is 2.1-fold (0.32 log units) below it; low and high end bracket the measured number.
By their numbers in this assay, from the lowest: compound 2; then compound 3; then compounds 4 and 1 (each within the scatter of the next).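

In this assay, inverting both stereocentres leaves the read-out unchanged within the scatter, with a 1.1-fold lower number from compound 1 to compound 4 (0.05 log units; within the scatter), so with methyl on the amine nitrogen these two mirror images cannot be told apart. Among these compounds, the same compound also provides the first counted step at that nitrogen, and it is far larger: methyl in place of hydrogen on an amine nitrogen in a ring gives a 62-fold higher number from compound 2 to compound 4 (1.79 log units; beyond the scatter), so the substituent on that nitrogen matters much more than the configuration of the methylated pair. The mirror-image comparison is a test of configuration alone, with no other structural change to account for the result: the fact that compounds 1 and 4 differ only in the configuration as drawn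

The compounds shown leave open whether configuration is equally silent when hydrogen sits on the amine nitrogen, which only the mirror image of compound 2 could settle. They also leave open whether the large step belongs to methyl in particular or would recur with a longer chain such as ethyl or with an acetyl group on the same nitrogen.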